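Bromo for methyl on a fused aromatic ring, twice

A few compounds are considered here, and "the series" means these few. Any claim that something is new, unique, unknown or untested is made for them only; others in the source may bear on it.

Compound 1 `COC(=O)[C@@]1(C)CC[C@@H]2C3=C1CC[C@@H](C)[C@]3(C)C[C@@H]1c3cc(C)ccc3N[C@H]21` is the starting point of the series. In a functional assay on HBL-100 cells (Homo sapiens) for inhibition, read by sulforhodamine B assay, with a stated time of 48 h (a higher number here means a weaker inhibitor of growth, a lower number a stronger inhibitor of growth), compound 1 gives 15000 nM. Compound 2 `COC(=O)[C@@]1(C)CC[C@@H]2C3=C1CC[C@@H](C)[C@]3(C)C[C@@H]1c3cc(Br)ccc3N[C@H]21` differs from it by a single substitution, (bromo in place of methyl on an aromatic carbon), and in this assay compound 2 gives 34000 nM. The step itself is a 2.3-fold higher number from compound 1 to compound 2 (0.36 log units; beyond the scatter).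

Compound 3 `COC(=O)[C@@]1(C)CC[C@@H]2C3=C1CC[C@@H](C)[C@]3(C)C[C@@H]1c3cccc(C)c3N[C@H]21` carries its methyl at another position of the aromatic ring; the difference between its core and the core of compound 1 is not broken down here. In this assay compound 3 gives 32000 nM, which sits close to compound 2 and beyond the scatter from compound 1.

Compound 4 `COC(=O)[C@@]1(C)CC[C@@H]2C3=C1CC[C@@H](C)[C@]3(C)C[C@@H]1c3cccc(Br)c3N[C@H]21` has not been measured. It differs from compound 3 by bromo in place of methyl on an aromatic carbon. This is the same kind of change as that from compound 1 to compound 2, but not the same: in compound 4 the exchanged position is ortho to a fused ring and meta to a fused ring, whereas in compound 2 it is meta to a fused ring and para to a fused ring.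

Among the measured compounds shown here, since only one such step is known, the expectation rests on it alone. In this assay compound 4 is expected to show a step of a 2.0-fold higher number from compound 3 to compound 4 (0.31 log units; beyond the scatter), by analogy to the modest rise seen in a 2.3-fold higher number from compound 1 to compound 2 (0.36 log units; beyond the scatter). Compound 4 is therefore estimated at 65000 nM, within a range of 25000 nM to 170000 nM.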

Compound 4, concentration for 50% growth inhibition: 40000 nM
Beside the measured number, compound 4's estimate is 1.6-fold (0.21 log units) above it; the measured number falls inside the stated range.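

In this assay, bromo in place of methyl on an aromatic carbon gives a 1.3-fold higher number from compound 3 to compound 4 (0.10 log units; within the scatter), so on this core the two compounds cannot be told apart, whereas on the core of compound 1 the same exchange gave a 2.3-fold higher number from compound 1 to compound 2 (0.36 log units; beyond the scatter). Set side by side, the two steps do not differ by more than repeated measurements would allow: the same change on two cores in this assay, a 2.3-fold higher number (0.36 log units; beyond the scatter) from compound 1 to compound 2 and a 1.3-fold higher number (0.10 log units; within the scatter) from compound 3 to compound 4, 1.8-fold (0.26 log units) apart, within the scatter of two such steps. The exchange therefore carries from one core to the other with no demonstrable difference, but one step just beyond the scatter and one within it do not establish that its effect is the same on both cores, nor that bromo is reliably a weaker choice than methyl in this series, and they offer no explanation for either result.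

The compounds shown carry only methyl or bromo on the aromatic ring, so it remains open how a chloro group, a methoxy group, an amine or a carboxylic acid would behave there on either core. From the compounds shown here alone, it also remains open how much the methyl ester shared by all four compounds matters, since no carboxylic acid or amide in its place appears among them.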